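The source may hold more compounds than are shown below. What is called first, only, known or untested is meant among the compounds shown, and "the series" means these compounds.

Measured so far in an ADME assay on MT4 cells (Homo sapiens) for cytotoxicity, read by MTT assay; a higher number here means that more compound is tolerated, a lower number that less compound is tolerated:
- compound 1 `CCOC(=O)/C(O)=C/C(=O)c1cn(Cc2ccc(F)c(F)c2F)c2cccc(OC)c12`: 42700 nM
- compound 2 `CCOC(=O)/C(O)=C/C(=O)c1cn(Cc2cccc(F)c2)c2cccc(OC)c12`: 63200 nM

Within the data shown here, only one step joins the two: a 1.5-fold higher number from compound 1 to compound 2 (0.17 log units; within the scatter). On these numbers compound 2 cannot be set apart from compound 1; the two values lie within the scatter of one another, so neither is the better tolerated.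

Compound 3 `CCOC(=O)/C(O)=C/C(=O)c1cn(Cc2c(F)cccc2F)c2cccc(OC)c12` differs from compound 2 in one place: 2,6-difluorophenyl in place of 3-fluorophenyl on a saturated chain carbon bound to an aromatic nitrogen. Among the measured compounds shown here, the only measured step that bears on this is the one from compound 1 to compound 2, which also swapped one fluorine pattern on the same phenyl at the same place and stayed within the scatter. For the measured compounds named here, no compound with the 2,6-difluorophenyl pattern has been measured, so there is no direct precedent for it. The expectation for compound 3 is therefore no step beyond the scatter, that is a 1.2-fold lower number from compound 2 to compound 3 (0.08 log units; within the scatter). The estimate for compound 3 in this assay is 52000 nM, with a range from 26000 nM to 105000 nM.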

Compound 3, half-maximal cytotoxic concentration: 63400 nM
Compound 3: the middle estimate sits 1.2-fold (0.09 log units) below what was measured; the measured number falls inside the stated range.
By their numbers in this assay, from the lowest: compounds 1, 2 and 3 (each within the scatter of the next).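

Moving to 2,6-difluorophenyl on a saturated chain carbon bound to an aromatic nitrogen gives, in this assay, no separable change from either earlier group (a 1.0-fold higher number from compound 2 to compound 3 (0.00 log units; within the scatter); a 1.5-fold higher number from compound 1 to compound 3 (0.17 log units; within the scatter)). The position has now taken 3-fluorophenyl, 2,6-difluorophenyl and 2,3,4-trifluorophenyl, and all three compounds lie within the scatter of one another, so among these fluorine patterns none can be set apart in this read-out. No supporting data are available to explain this flat result.

From the compounds shown here alone, whether the flatness extends beyond fluorinated phenyl groups remains open, for example to an unsubstituted phenyl or to a phenyl carrying an amine or a carboxylic acid. A longer chain in place of the benzyl link is equally untested by the compounds shown here.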